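Extending the ring methyl of compound 2 by one carbon

This account rests on a few compounds, and the source may have more. Where it says the series, first, only, none or still open, it means among the compounds named here.

Compound 1 `COc1ccc(-c2cc(-c3ccc(OC)cc3)on2)cc1` is measured in an ADME assay (Mus musculus) for antiproliferative activity, read by cell counting, with a stated time of 5 days; a lower number here means a stronger inhibitor, a higher number a weaker inhibitor. In this assay compound 1 gives > 100000 nM, which is a limit of the assay and not a number. Compound 2 `COc1ccc(-c2noc(-c3ccc(OC)cc3)c2C)cc1` carries a methyl in place of hydrogen on an aromatic carbon. In this assay compound 2 gives > 100000 nM, again a limit of the assay rather than a number. The step that the two limits leave unreadable from compound 1 to compound 2 therefore cannot be read, since both values sit at the limit of > 100000 nM in this assay, at which 2 of the 2 values shown sit. Compound 3 `CCc1c(-c2ccc(OC)cc2)noc1-c1ccc(OC)cc1` differs from compound 2 by methyl in place of hydrogen on a saturated chain carbon bound to an aromatic carbon. Among the compounds with values here, the only measured step bears on it in kind alone: it joins two limits and yields no size and no direction. No step beyond the scatter can be expected in this assay, and compound 3 is expected to sit at the limit as well, with an estimate of 150000 nM spanning 50000 nM to 500000 nM, which amounts to an expected step that the limit leaves unreadable from compound 2 to compound 3.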

Compound 3, half-maximal inhibitory concentration: > 100000 nM
Compound 3: only a limit was reported; the forecaster's own chance of this, stated with the estimate: 85%; the middle value is on the limit's open side.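

No new step can be read among compound 1, compound 2 and compound 3 in this assay, because all three values are limits of the assay and not numbers: the limit of > 100000 nM in this assay, at which 3 of the 3 values shown sit.

The compounds shown leave open whether the change from methyl to ethyl has any effect on antiproliferative activity, in size or in direction.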